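The source may report more compounds than this note shows. Statements on the series, on what has been measured and on what is new or still open speak of the compounds shown alone.

Measured so far in a functional assay on Hep 3B2 cells (Homo sapiens) for antiproliferative activity, read by MTT assay, with a stated time of 24 h, tested at 0.02 ug/mL; on this read-out lower numbers stand for a weaker effect and higher numbers for a stronger effect at the one concentration tested:
compound 1, `Cc1ccc2nc(C(=O)Nc3c(F)cc(-c4cccc(F)c4)cc3F)c(C)c(O)c2c1`: 0.98%
compound 2, `CCOc1ccc2nc(C(=O)Nc3c(F)cc(-c4cccc(F)c4)cc3F)c(C)c(O)c2c1`: -0.32%

Both readings sit close to zero and within the scatter of each other. Among the measured compounds shown here, the single step available, a number 1.3 percentage points lower from compound 1 to compound 2 (within the scatter), puts ethoxy in place of methyl on an aromatic carbon and alters nothing beyond the scatter; compound 1 therefore shows no effect in this assay that can be told apart from compound 2.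

Compound 3, `Cc1ccc2nc(C(=O)Nc3c(F)cc(-c4cccc(F)c4)cc3F)c(C)c(C(=O)O)c2c1`, is the next to be measured. It differs from compound 1 in carboxy in place of hydroxy on an aromatic carbon, opposite the ring nitrogen and ortho to a methyl group. For the measured compounds named here, no measured step concerns this aromatic carbon; the only step known involves a different aromatic carbon and stayed within the scatter. With both measured values near zero, the estimate for compound 3 is a step of a number 0.5 percentage points lower from compound 1 to compound 3 (within the scatter), meaning no change beyond the scatter. Compound 3 is expected to give 0.5%, with a range from -9% to 10%.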

Compound 3, a percentage reported as inhibition, at one concentration (the size of the read-out at that concentration, not a potency): 1.05%
For compound 3 the middle estimate is 0.6 percentage points below the measured one; measured number inside the range.
By their numbers in this assay, from the lowest: compounds 2, 1 and 3 (each within the scatter of the next).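

In this assay, carboxy in place of hydroxy on the aromatic carbon opposite the ring nitrogen and ortho to a methyl group gives a number 0.1 percentage points higher from compound 1 to compound 3 (within the scatter). Among the compounds shown here, this is the first reading at this position, since the earlier step concerned a different aromatic carbon, and the change here also stays inside the scatter, so neither position yet separates from the other at the one concentration tested. Nothing available on these compounds offers an explanation for this result.

With every reading in the series close to zero, the compounds shown do not tell whether any group at this carbon can move the number in this assay. Going by these compounds, an amine or a methoxy group on this carbon, or a longer chain in place of the methyl group ortho to it, remains open, as does the response of the series at higher concentrations.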